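The compounds below may be only part of what the source reports. "The series", "measured", "known", "first", "only" and "open" are said of these compounds alone.

Working notes on the series. All three measured compounds share one core and differ only in the group on the aromatic carbon of the five-membered ring. In a functional assay on MOLT-4 cells (Homo sapiens) for antiproliferative activity (a higher number here means a weaker inhibitor, a lower number a stronger inhibitor), compound 1 `COc1cc(C(=O)c2sc(-c3ccc(C(F)(F)F)cc3)cc2N)cc(OC)c1OC` gives 250 nM, the second highest of the three numbers: compound 2 `COc1cc(C(=O)c2sc(-c3cc(OC)c(OC)c(OC)c3)cc2N)cc(OC)c1OC` gives 1200 nM, while compound 3 `COc1cc(C(=O)c2sc(-c3ccsc3)cc2N)cc(OC)c1OC` gives 8.8 nM. Going by the values given here, the only single-point step available is a 28-fold lower number from compound 1 to compound 3 (1.45 log units; beyond the scatter), where thiophen-3-yl entered. Compound 4 `COc1cc(C(=O)c2sc(-c3ccncc3)cc2N)cc(OC)c1OC` differs from compound 1 by pyridin-4-yl in place of 4-(trifluoromethyl)phenyl on an aromatic carbon. Since a six-membered aromatic ring enters here rather than thiophen-3-yl, a smaller move than a 28-fold lower number from compound 1 to compound 3 (1.45 log units; beyond the scatter) is expected, toward a lower number or none beyond the scatter. Compound 4 is estimated at 150 nM, range 30 nM to 800 nM. That corresponds to an expected 1.7-fold lower number from compound 1 to compound 4 (0.22 log units; within the scatter).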

Compound 4, half-maximal inhibitory concentration: 88 nM
Estimate against measurement, compound 4: 1.7-fold (0.23 log units) above, within the range that was stated.
By their numbers in this assay, from the lowest: compound 3; then compound 4; then compound 1; then compound 2.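

Replacing the substituted phenyl on the aromatic carbon next to the ring sulfur with another six-membered aromatic ring gives a 2.8-fold lower number from compound 1 to compound 4 (0.45 log units; beyond the scatter) so a five-membered ring is not required for a lower number at this position. The choice of ring still matters, with a 10-fold higher number from compound 3 to compound 4 (1.00 log units; beyond the scatter) as the change from thiophen-3-yl to pyridin-4-yl. No measurement is available that bears on the reason for either step.

From the compounds shown here alone, whether a furan ring would track thiophen-3-yl remains open. So does the outcome with a non-aromatic group here, such as a morpholine or a simple amine.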